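A few compounds are considered here, and "the series" means these few. Any claim that something is new, unique, unknown or untested is made for them only; others in the source may bear on it.

Working notes on the series. In a functional assay on HepG2 cells (Homo sapiens) for antiproliferative activity, read by CCK-8 assay, with a stated time of 48 h (a lower number here means a stronger inhibitor, a higher number a weaker inhibitor), compound 1 (`COc1ccc(/C=C\c2cc(OC)c(OC)c(OC)c2)cc1OCc1ccc(CNCCO)cc1`) gives 5900 nM and compound 2 (`COc1ccc(/C=C\c2cc(OC)c(OC)c(OC)c2)cc1OCc1ccc(CN2CC[C@@H](O)C2)cc1`) gives 6200 nM, so compound 2 stands level with compound 1. Compound 3 (`COc1ccc(/C=C\c2cc(OC)c(OC)c(OC)c2)cc1OCc1ccc(CN2CCCCC2C(=O)NCCN)cc1`) differs from compound 2 by this change: 2-((2-aminoethyl)carbamoyl)piperidin-1-yl in place of 3-hydroxypyrrolidin-1-yl on a saturated chain carbon bound to an aromatic carbon (the new group is the larger one). Within the data shown here, the only measured step at this saturated chain carbon, a 1.1-fold higher number from compound 1 to compound 2 (0.02 log units; within the scatter), involves a smaller group, so it is a weak guide. Taking compound 2 as the basis, no step beyond the scatter is expected in this assay, and the expected change is a 1.1-fold lower number from compound 2 to compound 3 (0.05 log units; within the scatter) with no firm direction. Compound 3 is estimated at 5500 nM (range 1800 nM to 15000 nM).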

Compound 3, half-maximal inhibitory concentration: 4800 nM
For compound 3 the middle estimate is 1.1-fold (0.06 log units) above the measured one, within the range that was stated.
By their numbers in this assay, from the lowest: compounds 3, 1 and 2 (each within the scatter of the next).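

At this saturated chain carbon bound to an aromatic carbon, 2-((2-aminoethyl)carbamoyl)piperidin-1-yl in place of 3-hydroxypyrrolidin-1-yl gives a 1.3-fold lower number from compound 2 to compound 3 (0.11 log units; within the scatter) in this assay, and in place of (2-hydroxyethyl)amino it gives a 1.2-fold lower number from compound 1 to compound 3 (0.09 log units; within the scatter) in the same assay. Thus, a much larger group with a carbamoyl and an amine stands level with the two hydroxyl-bearing groups, which the earlier pair could not show. No supporting data bear on the reason for this. Open, going by these compounds, is whether a carboxylic acid or a longer chain on the carbamoyl nitrogen at this place would move the number beyond the scatter.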